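The source may report more compounds than this note shows. Statements on the series, on what has been measured and on what is new or still open speak of the compounds shown alone.

In a functional assay on HEY cells (Homo sapiens) for cytotoxicity, read by MTT assay, with a stated time of 72 h (on this read-out higher numbers stand for weaker inhibition and lower numbers for stronger inhibition), compound 1 (`N[C@H]1CC[C@H](Nc2c(C(=O)NCc3ccc(Cl)cc3Cl)nc(Br)c3cccnc23)CC1`) gives 5000 nM and compound 2 (`CN(C)c1ccc(CNC(=O)c2nc(Br)c3cccnc3c2N[C@H]2CC[C@H](N)CC2)cc1`) gives 5300 nM which leaves compound 2 level with compound 1 within the scatter. Compound 3 (`N[C@H]1CC[C@H](Nc2c(C(=O)NCc3cccs3)nc(Br)c3cccnc23)CC1`) has thiophen-2-yl in place of 4-(dimethylamino)phenyl on a saturated chain carbon bound to an amide-type nitrogen. Within the data shown here, the only measured step at that place, a 1.1-fold higher number from compound 1 to compound 2 (0.03 log units; within the scatter) with 4-(dimethylamino)phenyl in place of 2,4-dichlorophenyl, stayed within the scatter, so no step beyond the scatter is expected in this assay. The expected step is a 1.1-fold lower number from compound 2 to compound 3 (0.03 log units; within the scatter) and rests on that single comparison. For compound 3 the estimate is 5000 nM with an expected range of 2200 nM to 11000 nM on this read-out.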

Compound 3, half-maximal inhibitory concentration: 11000 nM
For compound 3 the middle estimate is 2.2-fold (0.34 log units) below the measured one; low and high end bracket the measured number.
By their numbers in this assay, from the lowest: compounds 1 and 2 (each within the scatter of the next); then compound 3.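

Among these compounds, at the place on a saturated chain carbon bound to an amide-type nitrogen, thiophen-2-yl is the first change to move the number in this assay beyond the scatter, with a 2.1-fold higher number from compound 2 to compound 3 (0.32 log units; beyond the scatter) and a 2.2-fold higher number from compound 1 to compound 3 (0.34 log units; beyond the scatter) both modest and toward weaker inhibition. This position therefore does respond to the group it carries, although 2,4-dichlorophenyl and 4-(dimethylamino)phenyl stay level. No available evidence explains this step. From the compounds shown here alone, whether the shift follows the sulfur, the five-membered ring or the lower heavy-atom count stays open. Unsubstituted phenyl, furan-2-yl or a longer chain to the ring could help separate these readings.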